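A few compounds are considered here, and "the series" means these few. Any claim that something is new, unique, unknown or untested is made for them only; others in the source may bear on it.

Compound 1, `NCc1ccc(NC(=O)N(CCCCO)Cc2ccc(C(=O)NO)cc2)cc1`. In an assay on HEK293 cells for inhibition of histone deacetylase 11 (Homo sapiens), read by fluorescence, with stated times of 10 min and 30 min (on this read-out lower numbers stand for stronger inhibition and higher numbers for weaker inhibition), compound 1 gives > 50000 nM, which is a limit of the assay.
Compound 2, `CCCCN(Cc1ccc(C(=O)NO)cc1)C(=O)Nc1ccc(CN)cc1`. In this assay compound 2 gives > 50000 nM, again a limit.

Compound 1 thus sits at the limit of > 50000 nM in this assay, at which 2 of the 2 values shown sit. The unmeasured compound 3, `O=C(NO)c1ccc(CN(CCCCO)C(=O)Nc2ccccc2)cc1`, differs from compound 1 by hydrogen in place of aminomethyl on an aromatic carbon. Within the data shown here, the single measured step, a step that the two limits leave unreadable from compound 1 to compound 2, runs between two limits and has no readable size, so no measured step tells the size or direction of this change. Compound 3 is therefore expected to remain at the limit as well, with an expected step that the limit leaves unreadable from compound 1 to compound 3. Compound 3 is estimated at 60000 nM, in a range from 20000 nM to 200000 nM.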

Compound 3, half-maximal inhibitory concentration: > 50000 nM
Compound 3 ended at the assay's limit; the forecaster's own chance of this, stated with the estimate: 85%; the middle value does not contradict the limit.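

Compound 1 and compound 3 both stand at a limit of the assay, so no step between them can be read: the limit of > 50000 nM in this assay, at which 3 of the 3 values shown sit.

The compounds shown leave open how strongly any of them inhibits, and whether losing the aminomethyl changes that at all.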